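Cyclohexyl in Place of Phenylethyl on an Acylguanidine

A few compounds are considered here, and "the series" means these few. Any claim that something is new, unique, unknown or untested is made for them only; others in the source may bear on it.

Measured so far:
compound 1, `Cc1nc(N)sc1CCCN/C(N)=N/C(=O)N[C@H](C)c1ccccc1`: 45.7 nM
compound 2, `N/C(=N\C(=O)NCc1ccccc1)NC1CCc2nc(N)sc2C1`: 4370 nM
compound 3, `Cc1nc(N)sc1CCCN/C(N)=N/C(=S)N[C@H](C)c1ccccc1`: 372 nM

In a functional assay on HEK293T cells for agonist activity at histamine H2 receptor (Homo sapiens), read by beta-arrestin recruitment (on this read-out higher numbers stand for an effect only at larger amounts of compound and lower numbers for an effect already at smaller amounts), compound 1 gives 45.7 nM, the lowest of the three numbers. Compound 3 stands nearest to it and compound 2 furthest, and both gaps lie beyond the scatter. Compound 4, `Cc1nc(N)sc1CCCN/C(N)=N/C(=O)NC1CCCCC1`, has not yet been measured. It differs from compound 1 in a single place: cyclohexyl in place of 1-phenylethyl on an amide-type nitrogen. Within the data shown here, no two measured compounds differ in one place alone, so no measured step speaks directly to this change. The expected step is a 1.8-fold higher number from compound 1 to compound 4 (0.24 log units; within the scatter), a modest rise that may well stay within the scatter. For compound 4 the estimate in this assay is 80 nM, with a range from 25 nM to 300 nM.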

Compound 4, half-maximal effective concentration: 389 nM
Estimate against measurement, compound 4: 4.9-fold (0.69 log units) below; measured number outside the range, above it.
By their numbers in this assay, from the lowest: compound 1; then compounds 3 and 4 (each within the scatter of the next); then compound 2.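

In this assay, among these compounds, the swap of 1-phenylethyl for cyclohexyl on the amide-type nitrogen gives an 8.5-fold higher number from compound 1 to compound 4 (0.93 log units; beyond the scatter) and is the first single-place step in this set. It shows that this nitrogen substituent is not freely exchangeable, since one ring of six carbons does not stand in for the other here. The change removes an aromatic ring and the defined stereocentre together, and the step cannot divide its size between them.

A 1-cyclohexylethyl group or a plain phenyl would help separate these two changes. Nothing available here explains the step.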